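Swapping a pyrazole ring for ethyl on a ghrelin receptor ligand

The source may report more compounds than this note shows. Statements on the series, on what has been measured and on what is new or still open speak of the compounds shown alone.

Three related compounds have been measured in an assay on HEK293 cells for displacement of a labelled ligand from growth hormone secretagogue receptor type 1 (Homo sapiens), with a stated time of 60 min; on this read-out lower numbers stand for stronger inhibition and higher numbers for weaker inhibition. Compound 1 `Cc1cc(C)n(-c2ccc(Cl)c(C(=O)NC(=O)Nc3nc4ccc(S(=O)(=O)CCCN5CCN(C)CC5)cc4s3)c2)n1` gives 1.3 nM. Compound 2 `COc1cc(Cl)c(C(=O)NC(=O)Nc2nc3ccc(S(=O)(=O)CCCN4CCN(C)CC4)cc3s2)cc1-n1cccn1` gives 0.62 nM, a lower number than compound 1, while compound 3 `Cc1ccnn1-c1ccc(Cl)c(C(=O)NC(=O)Nc2nc3ccc(S(=O)(=O)C4CCN(C)CC4)cc3s2)c1` gives 33 nM, a far higher number. Compound 1 thus holds the second highest of the three numbers, with compound 2 nearest and compound 3 furthest from it.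

Compound 4 `CCc1ccc(Cl)c(C(=O)NC(=O)Nc2nc3ccc(S(=O)(=O)CCCN4CCN(C)CC4)cc3s2)c1` has not been measured. It differs from compound 1 in one place: ethyl in place of 3,5-dimethyl-1H-pyrazol-1-yl on an aromatic carbon. Among the measured compounds shown here, no measured pair shows this kind of change, so the step is uncertain; replacing a ring by a small chain is expected to weaken binding moderately, and the step in this assay from compound 1 to compound 4 is estimated at a 6.2-fold higher number from compound 1 to compound 4 (0.79 log units; beyond the scatter). For compound 4 the expected value is 8 nM, within a range of 2 nM to 40 nM.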

Compound 4, half-maximal inhibitory concentration: 0.078 nM
Estimate against measurement, compound 4: 100-fold (2.01 log units) above, and the stated range ends above it.
By their numbers in this assay, from the lowest: compound 4; then compound 2; then compound 1; then compound 3.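

At this aromatic carbon, para to a chloro group, the pyrazole ring is not needed for strong inhibition: changing 3,5-dimethyl-1H-pyrazol-1-yl to ethyl gives a 17-fold lower number from compound 1 to compound 4 (1.22 log units; beyond the scatter). All three earlier compounds carry a pyrazole ring at this place, so they could not show that a small chain with no ring and no hydrogen-bond acceptors works here. Nothing measured here explains the stronger inhibition. As far as these compounds go, whether methyl, propyl or a longer chain matches ethyl stays open. So does whether ethyl would give a similar step in compound 3, which also differs elsewhere.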